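This account rests on a few compounds, and the source may have more. Where it says the series, first, only, none or still open, it means among the compounds named here.

Compound 1 `COC(c1cc(Cl)c2c(c1Cl)C(=O)N(Cc1c(C)cc(C)[nH]c1=O)CC2)C1CCOCC1`: 130 uL/min; 129 uL/min (2 entries) in an ADME assay on microsomes from liver (Homo sapiens) for metabolic stability, read by LC-MS, using NADPH, with stated times of 10 min and 45 min, tested at 1 uM; on this read-out lower numbers stand for slow clearance and higher numbers for fast clearance.
Compound 2 `Cc1cc(C)c(CN2CCc3c(Cl)cc([C@H](CO)[C@H]4CCCO4)c(Cl)c3C2=O)c(=O)[nH]1`: 51.6 uL/min.

Compound 1 has two entries that agree closely, (the several entries of compound 1 in this assay, 130 uL/min; 129 uL/min (2 entries)). Compound 2 stands on the lower of the two values shown, and a further entry for compound 2 gave no single number. Compound 3 `Cc1cc(C)c(CN2CCc3c(Cl)cc([C@@H](CO)[C@@H]4CCOC4)c(Cl)c3C2=O)c(=O)[nH]1` differs from compound 2 only in a group of 8 heavy atoms (6 carbon, 2 oxygen; one five-membered non-aromatic ring with 1 hetero atom) in place of a group of 8 heavy atoms (6 carbon, 2 oxygen; one five-membered non-aromatic ring with 1 hetero atom), on an aromatic carbon; the two have the same atoms, joined differently. Within the data shown here, no step between measured compounds is available to lean on, so the expected step of a 1.1-fold higher number from compound 2 to compound 3 (0.03 log units; within the scatter) in this assay is small, not beyond the usual scatter. Compound 3 is therefore estimated at 55 uL/min, with a range from 25 uL/min to 120 uL/min.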

Compound 3, intrinsic clearance in a liver preparation (reported as CLH), per the amount of preparation that the assay uses: 25.3 uL/min
Beside the measured number, compound 3's estimate is 2.2-fold (0.34 log units) above it, within the range that was stated.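

At this aromatic carbon, joining the same atoms differently gives a 2.0-fold lower number from compound 2 to compound 3 (0.31 log units; beyond the scatter) in this assay, so the read-out responds to how this group is put together, not only to which atoms it holds. The step is modest, but repeat entries for a compound on the same read-out can sit close together: the several entries of compound 1 in this assay, 130 uL/min; 129 uL/min (2 entries)

Among these compounds, with only this one pair, which feature of the rearranged group carries the step stays unknown. As far as these compounds go, how an amine, a carboxylic acid or a longer chain on this aromatic carbon would fare also remains open.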